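Adding one methyl group: tolerance across the series

This account rests on a few compounds, and the source may have more. Where it says the series, first, only, none or still open, it means among the compounds named here.

In an ADME assay on THP-1 cells (Homo sapiens) for cytotoxicity, read by MTT assay (a higher number here means that more compound is tolerated, a lower number that less compound is tolerated), compound 3 (`Cc1nc(-c2cccnc2)sc1-c1nnc(-c2ccccc2)o1`) gives > 100 ug/mL, which is a limit of the assay and not a number. Compound 1 (`Cc1nc(-c2cccnc2)sc1-c1nnc(Cc2ccccc2)o1`) gives > 100 ug/mL, also a limit. Compound 2 (`Cc1nc(-c2cccnc2)sc1-c1nnc(-c2ccc([N+](=O)[O-])cc2)o1`) gives > 100 ug/mL, again a limit. The measured compounds therefore stand together: the limit of > 100 ug/mL in this assay, at which 3 of the 3 values shown sit.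

Compound 4 (`Cc1cccc(-c2nnc(-c3sc(-c4cccnc4)nc3C)o2)c1`) differs from compound 3 by methyl in place of hydrogen on an aromatic carbon, meta to a large group.

Within the data shown here, two measured steps bear on this change: a step that the two limits leave unreadable from compound 1 to compound 3 and a step that the two limits leave unreadable from compound 2 to compound 3. Neither has a readable size, and neither gives a direction. A step beyond the scatter in this assay is therefore not expected, and no direction is expected. The expected step is a step that the limit leaves unreadable from compound 3 to compound 4. The estimate for compound 4 is 120 ug/mL, with an expected range of 60 ug/mL to 250 ug/mL.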

Compound 4, half-maximal cytotoxic concentration: > 100 ug/mL
Compound 4 was reported as a limit; the forecaster's own chance of this, stated with the estimate: 85%; the middle value is on the limit's open side.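

In this assay, among these compounds, compound 4 gives > 100 ug/mL, a limit of the assay and not a number, so no step from compound 3 or compound 1 to compound 4 can be read. The compounds shown leave open whether methyl in place of hydrogen on an aromatic carbon changes tolerance at all, since all four sit at the same limit.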